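Terminal hydroxy on the sulfonyl chain, second core

The source may report more compounds than this note shows. Statements on the series, on what has been measured and on what is new or still open speak of the compounds shown alone.

Compound 1 `CCCc1cnc(N2CCC(C3Cc4cc(C5=CCN(S(=O)(=O)CCC)CC5)cc(F)c4O3)CC2)nc1` and compound 2 `CCCc1cnc(N2CCC(C3(C)Cc4cc(C5=CCN(S(=O)(=O)CCC)CC5)ccc4O3)CC2)nc1` share the propyl sulfonyl group but stand on different cores; the difference between the two cores is not broken down here. In a functional assay on HEK293 cells for agonist activity at Glucose-dependent insulinotropic receptor (Homo sapiens), read by cAMP accumulation, with a stated time of 60 min (on this read-out lower numbers stand for an effect already at smaller amounts and higher numbers for an effect only at larger amounts of compound), compound 1 gives 62 nM and compound 2 gives 70 nM, values that lie within the scatter of each other. Compound 3 `CCCc1cnc(N2CCC(C3Cc4cc(C5=CCN(S(=O)(=O)CCCO)CC5)cc(F)c4O3)CC2)nc1` carries hydroxy in place of hydrogen on a saturated chain carbon, three bonds along the chain from a sulfonyl sulfur relative to compound 1, and in this assay compound 3 gives 122 nM. This reads as a 2.0-fold higher number from compound 1 to compound 3 (0.29 log units; within the scatter), a step that stays within the scatter.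

Compound 4 `CCCc1cnc(N2CCC(C3(C)Cc4cc(C5=CCN(S(=O)(=O)CCCO)CC5)ccc4O3)CC2)nc1` is the unmeasured partner of compound 2 and carries the same change, (hydroxy in place of hydrogen on a saturated chain carbon, three bonds along the chain from a sulfonyl sulfur). The place of the change is the same word for word in both pairs, so the change is the same, and it occurs twice among the compounds shown, once with a measured outcome and once open. The expectation for compound 4 rests on a single measured step, so its transfer to the core of compound 2 is not secured beyond the scatter. For compound 4 the expected step in this assay is a 2.0-fold higher number from compound 2 to compound 4 (0.30 log units; within the scatter), and this rests on a 2.0-fold higher number from compound 1 to compound 3 (0.29 log units; within the scatter). Compound 4 is therefore estimated to give 140 nM in this assay, with an expected range from 70 nM to 280 nM.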

Compound 4, half-maximal effective concentration: 78 nM
Beside the measured number, compound 4's estimate is 1.8-fold (0.25 log units) above it; the range from low to high includes it.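

On the second core, in this assay, hydroxy in place of hydrogen on a saturated chain carbon, three bonds along the chain from a sulfonyl sulfur, gives a 1.1-fold higher number from compound 2 to compound 4 (0.05 log units; within the scatter). Set side by side, the readings of this change on the two cores do not differ beyond what repeat measurements would give: the same change on two cores in this assay, a 2.0-fold higher number (0.29 log units; within the scatter) from compound 1 to compound 3 and a 1.1-fold higher number (0.05 log units; within the scatter) from compound 2 to compound 4, 1.8-fold (0.25 log units) apart, within the scatter of two such steps. The change, propyl to 3-hydroxypropyl on the sulfonyl group, can therefore be carried between these two cores with no step beyond the scatter on either, but since both steps lie within the scatter, the data do not show that the change has a real effect on either core or that its size is the same on both, and two cores say nothing about any further core.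

The compounds shown leave open what other groups at the end of the sulfonyl chain would do on either core, such as an amine, a carboxylic acid or a longer chain carrying the hydroxy. For the compounds shown here, they also leave open how the separate differences between the core of compound 1 and the core of compound 2 contribute, as no compound here varies them one at a time.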